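The compounds below may be only part of what the source reports. "The series", "measured", "known", "first", "only" and "open" are said of these compounds alone.

Compound 1 `COc1cc(OCc2cccc(-c3ccc(C(F)(F)F)cn3)c2)c2cc(-c3cn4nc(OC)sc4n3)oc2c1`: 459 ng.h/mL
Compound 2 `CNC(=O)c1ccc(-c2nc(COc3cc(OC)cc4oc(-c5cn6nc(OC)sc6n5)cc34)cs2)cc1`: 21.9 ng.h/mL

In an ADME assay on the whole organism (Rattus norvegicus), at a dose of 2 mg/kg by the oral route (on this read-out lower numbers stand for lower exposure and higher numbers for higher exposure at the dose given), compound 1 gives 459 ng.h/mL and stands highest of the two measured compounds. Compound 2 gives 21.9 ng.h/mL and lies under it by a gap beyond the usual scatter.

Compound 3 `COc1cc(OCc2cccc(-c3ccc(C#N)cc3)c2)c2cc(-c3cn4nc(OC)sc4n3)oc2c1` keeps the core of compound 1 and changes one group, on an aromatic carbon of a six-membered aromatic ring of carbon only, meta to a large group. There, 4-cyanophenyl stands in place of 5-(trifluoromethyl)pyridin-2-yl: 4-cyanophenyl in place of 5-(trifluoromethyl)pyridin-2-yl on an aromatic carbon (the only difference between the two structures).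

For the measured compounds named here, no pair of measured compounds differs in one place only, so nothing measured sizes this exchange directly. In this assay, going by the values given here, a moderate step downward is expected, since compound 1 at 459 ng.h/mL holds the higher of only two values and compound 2 at 21.9 ng.h/mL shows that much lower numbers occur. The expected step is a 2.4-fold lower number from compound 1 to compound 3 (0.38 log units; beyond the scatter) and it remains an estimate. For compound 3 the estimated value is 190 ng.h/mL (expected range 50 ng.h/mL to 700 ng.h/mL).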

Compound 3, area under the concentration-time curve: 610 ng.h/mL
For compound 3 the middle estimate is 3.2-fold (0.51 log units) below the measured one; measured number inside the range.
By their numbers in this assay, from the lowest: compound 2; then compounds 1 and 3 (each within the scatter of the next).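

In this assay the exchange of 5-(trifluoromethyl)pyridin-2-yl for 4-cyanophenyl on an aromatic carbon of a six-membered aromatic ring of carbon only gives a 1.3-fold higher number from compound 1 to compound 3 (0.12 log units; within the scatter) and so leaves the two compounds indistinguishable on this read-out. For the compounds shown here, this is the first single-place step available, and it shows that at this position, meta to a large group, the ring nitrogen and the trifluoromethyl group can give way to a carbon-only ring bearing a nitrile with no change in exposure beyond the scatter at the dose given. No supporting measurement bears on why the two groups end up level.

Going by these compounds, both groups compared here are six-membered aromatic rings with one hydrogen-bond acceptor each, so it remains open whether this position would hold its exposure with a different kind of group, such as an amine, a carboxylic acid or a longer saturated chain. On these data alone, it also remains open whether the same exchange would give a similar step on a compound with other changes elsewhere in the structure.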